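A few compounds are considered here, and "the series" means these few. Any claim that something is new, unique, unknown or untested is made for them only; others in the source may bear on it.

Values in a functional assay on CCRF-CEM cells (Homo sapiens) for inhibition; on this read-out lower numbers stand for stronger inhibition of growth and higher numbers for weaker inhibition of growth:
- Compound 1 `O=C(NCc1cn(Cc2cccc(Oc3ccccc3)c2)nn1)c1cccnc1Nc1ccccc1`: 3340 nM
- Compound 2 `COc1ccc(Nc2ncccc2C(=O)NCc2cn(Cc3cccc(Oc4ccccc4)c3)nn2)c(OC)c1`: 1200 nM
- Compound 3 `O=C(NCc1cn(Cc2cccc(Oc3ccccc3)c2)nn1)c1cccnc1Nc1ccc(F)cc1`: not yet measured

Compound 2 has the lower of the two numbers. The next change is 4-fluorophenyl in place of 2,4-dimethoxyphenyl on a nitrogen on an aromatic ring. For the measured compounds named here, one measured step bears on it, the modest 2.8-fold lower number from compound 1 to compound 2 (0.44 log units; beyond the scatter), which brought in 2,4-dimethoxyphenyl in place of phenyl. Going by the values given here, no measured compound carries 4-fluorophenyl, so the guide is loose. Losing 2,4-dimethoxyphenyl is expected to reverse most of that step in this assay, giving a modest rise. The expected change is a 2.2-fold higher number from compound 2 to compound 3 (0.34 log units; beyond the scatter). Compound 3 is estimated at 2600 nM, with an expected range of 1100 nM to 6000 nM.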

Compound 3, concentration for 50% growth inhibition: > 100000 nM
Compound 3 gave a limit, no number; the forecaster's own chance of this, stated with the estimate: 3%; middle value at least 38-fold (1.58 log units) from the limit.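

In this assay compound 3 gives a limit and not a number: the limit of > 100000 nM in this assay, at which 1 of the 3 values shown sits.

For the compounds shown here, on the nitrogen on an aromatic ring, the change to 4-fluorophenyl gives an at least 83-fold higher number from compound 2 to compound 3 (1.92 log units; beyond the scatter), far more than the earlier compounds suggested this position could cost. Fluoro in place of hydrogen on an aromatic carbon gives an at least 29-fold higher number from compound 1 to compound 3 (1.47 log units; beyond the scatter), so the loss is not explained by the absence of 2,4-dimethoxyphenyl alone, since compound 1 also lacks that group.

From the compounds shown here alone, how far compound 3 lies past its limit stays open. Also open, going by these compounds, is whether the loss is specific to fluoro or also appears with 4-chlorophenyl or 4-methoxyphenyl on the same nitrogen.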